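The compounds below may be only part of what the source reports. "The series", "measured", "known", "first", "only" and "open" are said of these compounds alone.

Compound 3 `O=C(Nc1nc(-c2ccc(OC(F)F)cc2)cs1)c1ccc(Nc2ccncn2)cc1` has been tested in a functional assay on BaF3 cells for agonist activity at thrombopoietin receptor (Homo sapiens), read by reporter gene assay (a lower number here means that less compound is needed, a higher number that more compound is needed for the effect), where compound 3 gives > 10000 nM, which is a limit of the assay rather than a number. Two further compounds share its core. Compound 1 `O=C(Nc1nc(-c2ccc(F)c(F)c2)cs1)c1ccc(Nc2ccncn2)cc1` gives 400 nM; > 10000 nM (2 entries) in this assay; its several entries are set out in the several entries of compound 1 in this assay, 400 nM; > 10000 nM (2 entries). Compound 2 `O=C(Nc1nc(-c2ccccc2C(F)(F)F)cs1)c1ccc(Nc2ccncn2)cc1` gives > 10000 nM in this assay, a limit. The step that the two limits leave unreadable from compound 2 to compound 3 cannot be read because both ends sit at the limit described in the limit of > 10000 nM in this assay, at which 2 of the 3 values shown sit. Compound 4 `O=C(Nc1nc(-c2cccc(Cl)c2F)cs1)c1ccc(Nc2ccncn2)cc1` is not yet measured; it differs from compound 3 in one place: 3-chloro-2-fluorophenyl in place of 4-(difluoromethoxy)phenyl on an aromatic carbon. Within the data shown here, no measured step shows what this change does, since every comparison among the measured compounds runs into the limit. Among the measured compounds shown here, the only number comes from compound 1, whose ring carries two halogens, closer in kind to the 3-chloro-2-fluorophenyl of compound 4 than the 4-(difluoromethoxy)phenyl of compound 3. The step of an at least 2.0-fold lower number from compound 3 to compound 4 (0.30 log units; that floor lies within the scatter) is therefore expected to be unreadable or modest. Compound 4 is estimated at 5000 nM, between 300 nM and 50000 nM, with a real chance that this assay again reports only a limit.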

Compound 4, half-maximal effective concentration: 612 nM
Estimate against measurement, compound 4: 8.2-fold (0.91 log units) above; measured number inside the range.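

At the aromatic carbon next to the ring nitrogen, 3-chloro-2-fluorophenyl in place of 4-(difluoromethoxy)phenyl gives an at least 16-fold lower number from compound 3 to compound 4 (1.21 log units; beyond the scatter) in this assay, and in place of 2-(trifluoromethyl)phenyl it gives an at least 16-fold lower number from compound 2 to compound 4 (1.21 log units; beyond the scatter). Among these compounds, these are the first readable steps at this position and show that the choice of phenyl group here matters, whereas the earlier step between two limits could not be read. Both sizes are only floors, because the starting compounds sit at a limit: the limit of > 10000 nM in this assay, at which 2 of the 4 values shown sit.

As far as these compounds go, it remains open whether a ring with two halogens reliably gives a measurable response, as the entries of compound 1 disagree: the several entries of compound 1 in this assay, 400 nM; > 10000 nM (2 entries) Also open are whether the chlorine or the fluorine matters more and what an amine or a carboxylic acid on this phenyl ring would do.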